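From 3-chlorophenyl to 2-chlorophenyl: compound 3 awaited

This account rests on a few compounds, and the source may have more. Where it says the series, first, only, none or still open, it means among the compounds named here.

- compound 1 `CC(Oc1ccc(Cl)cc1Cl)C(=O)NCc1cccc(F)c1`: 27000 nM
- compound 2 `CC(Oc1ccc(Cl)cc1Cl)C(=O)NCc1cccc(Cl)c1`: 19000 nM

In an ADME assay on CHO cells (Cricetulus griseus) for cytotoxicity, read by LDH release (on this read-out higher numbers stand for weaker inhibition and lower numbers for stronger inhibition), compound 2 gives 19000 nM, and compound 1 lies within the scatter of it. Compound 3 `CC(Oc1ccc(Cl)cc1Cl)C(=O)NCc1ccccc1Cl` has the same atoms as compound 2, joined differently: 2-chlorophenyl in place of 3-chlorophenyl on a saturated chain carbon bound to an amide-type nitrogen. Here 2-chlorophenyl stands in place of 3-chlorophenyl on a saturated chain carbon bound to an amide-type nitrogen. For the measured compounds named here, the only measured step, a 1.4-fold lower number from compound 1 to compound 2 (0.15 log units; within the scatter), swaps fluoro for chloro and offers only indirect guidance, since no measured step moves the chlorine. No change beyond the scatter is therefore expected, and no direction can be favoured. The expected step is a 1.1-fold higher number from compound 2 to compound 3 (0.02 log units; within the scatter). For compound 3 the estimated value is 20000 nM, with an expected range from 10000 nM to 38000 nM.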

Compound 3, half-maximal inhibitory concentration: > 100000 nM
Compound 3 gave a limit, no number; the forecaster's own chance of this, stated with the estimate: 15%; middle value at least 5.0-fold (0.69 log units) from the limit.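

In this assay compound 3 gives only a limit of the assay, not a number: the limit of > 100000 nM in this assay, at which 1 of the 3 values shown sits.

Moving the chlorine from 3-chlorophenyl to 2-chlorophenyl gives an at least 5.2-fold higher number from compound 2 to compound 3 (0.72 log units; beyond the scatter), so at this place the position of the halogen matters, which the fluoro-to-chloro swap alone did not show. Set against 3-fluorophenyl, the change gives an at least 3.7-fold higher number from compound 1 to compound 3 (0.56 log units; beyond the scatter), also beyond the scatter.

As far as these compounds go, how far compound 3 really lies past its limit stays open. So does whether a methoxy group or an amine in place of the chlorine on 2-chlorophenyl would keep the number this high.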